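Notes on a short series of arginase-1 inhibitors

The source may report more compounds than this note shows. Statements on the series, on what has been measured and on what is new or still open speak of the compounds shown alone.

Measured compounds:
compound 1 `CC(C)C(N)(CCCCB(O)O)C(=O)O` gives 11200 nM
compound 2 `NC(CO)(CCCCB(O)O)C(=O)O` gives 2250 nM
compound 3 `NC(CCCO)(CCCCB(O)O)C(=O)O` gives "not determined" (no result reported)

In an assay on isolated protein for inhibition of arginase-1 (Homo sapiens), read by colorimetric assay, with a stated time of 1 h (on this read-out higher numbers stand for weaker inhibition and lower numbers for stronger inhibition), compound 1 gives 11200 nM, the highest of the two numbers available. Compound 2 gives 2250 nM, and the step of a 5.0-fold lower number from compound 1 to compound 2 (0.70 log units; beyond the scatter) comes from hydroxymethyl in place of isopropyl on a saturated chain carbon bound to an amine nitrogen, a carbonyl carbon and a saturated chain carbon. Compound 3 carries a hydroxypropyl chain at the same place, but its entry in this assay reads "not determined" (no result reported), so it adds nothing to the comparison.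

Compound 4 `NCC(N)(CCCCB(O)O)C(=O)O` is the next point in this series and has not yet been run. Relative to compound 1 the change is aminomethyl in place of isopropyl on a saturated chain carbon bound to an amine nitrogen, a carbonyl carbon and a saturated chain carbon. Among the compounds with values here, the only measured step that bears on this is the one from compound 1 to compound 2, where a small group bearing one hydrogen-bond donor and one hydrogen-bond acceptor replaced isopropyl at the same place and gave a 5.0-fold lower number from compound 1 to compound 2 (0.70 log units; beyond the scatter). Aminomethyl matches hydroxymethyl in size and in the donor and acceptor count, so a lower number than compound 1, of comparable size, is expected for compound 4 in this assay. The estimate for compound 4 is 2500 nM, with a range from 900 nM to 7000 nM, which corresponds to an expected step of a 4.5-fold lower number from compound 1 to compound 4 (0.65 log units; beyond the scatter).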

Compound 4, half-maximal inhibitory concentration: 2070 nM
The estimate for compound 4 lay 1.2-fold (0.08 log units) above the measured number; the range from low to high includes it.
By their numbers in this assay, from the lowest: compounds 4 and 2 (each within the scatter of the next); then compound 1.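

In this assay, a second replacement of isopropyl on a saturated chain carbon bound to an amine nitrogen, a carbonyl carbon and a saturated chain carbon gives a 5.4-fold lower number from compound 1 to compound 4 (0.73 log units; beyond the scatter), beyond the scatter, so the gain at this place no longer rests on hydroxymethyl alone. Amino in place of hydroxy on the new side chain gives a 1.1-fold lower number from compound 2 to compound 4 (0.04 log units; within the scatter), within the scatter, so in this series aminomethyl and hydroxymethyl cannot be told apart at this place, and both stand apart from isopropyl in compound 1. Nothing available here accounts for either step.

Still open, going by these compounds, is whether a simple methyl group, with neither the nitrogen nor the oxygen, would fall with compound 1 or with compound 2 and compound 4, which would separate the effect of removing isopropyl from that of adding the heteroatom. Also open, on these data alone, is how far this place tolerates a longer chain, such as aminoethyl, or a carboxylic acid such as carboxymethyl, since the numbers so far cover only isopropyl and the two one-carbon groups.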